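Series notes: removing the 4-fluorophenyl from compound 2

A few compounds are considered here, and "the series" means these few. Any claim that something is new, unique, unknown or untested is made for them only; others in the source may bear on it.

Of the compounds shown here, three have been measured in a functional assay on HCT-116 cells (Homo sapiens) for cytotoxicity, read by MTT assay, with a stated time of 48 h; a lower number here means a stronger inhibitor, a higher number a weaker inhibitor. Compound 1 `CN(C)CCCCCSC1=Nc2ccccc2C(CC(=O)NCc2ccc(F)cc2)N1c1ccc(-c2ccccc2)cc1` gives 6400 nM. Compound 2 `CN(C)CCCCCSC1=Nc2ccccc2C(CC(=O)NCc2ccccc2)N1c1ccc(-c2ccc(F)cc2)cc1` gives 9200 nM, which is the second highest of the three numbers; its nearest neighbour is compound 1, and that gap lies within the scatter, so no order between compound 1 and compound 2 can be read from these two values. Compound 3 `O=C(CC1c2ccccc2N=C(SCCCCCN2CCCC2)N1c1ccccc1)NCc1ccc(F)cc1` gives 27100 nM, the highest number of the three and beyond the scatter from compound 2; compound 3 differs from compound 2 in more than one place, so its value is noted only as it stands.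

The next compound is compound 4 `CN(C)CCCCCSC1=Nc2ccccc2C(CC(=O)NCc2ccccc2)N1c1ccccc1`. It differs from compound 2 in one place: hydrogen in place of 4-fluorophenyl on an aromatic carbon. Among the measured compounds shown here, no pair of measured compounds differing in exactly this way is available, so the size of the step is not known from the data.

The expected step in this assay from compound 2 to compound 4 is moderate and toward a higher number, that is toward weaker inhibition, with real uncertainty about whether it lies beyond the scatter; the estimate is a 2.2-fold higher number from compound 2 to compound 4 (0.34 log units; beyond the scatter). For compound 4 the estimated value in this assay is 20000 nM, within a range of 7000 nM to 60000 nM.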

Compound 4, half-maximal inhibitory concentration: 38800 nM
The estimate for compound 4 lay 1.9-fold (0.29 log units) below the measured number; the range from low to high includes it.
By their numbers in this assay, from the lowest: compounds 1 and 2 (each within the scatter of the next); then compounds 3 and 4 (each within the scatter of the next).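

In this assay, among the compounds shown here, hydrogen in place of 4-fluorophenyl on this aromatic carbon gives a 4.2-fold higher number from compound 2 to compound 4 (0.63 log units; beyond the scatter) and is the first change that can be read in one place. The earlier compounds shown here offered no such pair, so the contribution of this position remained unknown; it is now clear that, in this pair, removing the whole group moves the number toward weaker inhibition by more than the scatter. This single step covers the loss of the aromatic ring and its fluorine together, so it does not assign the shift to either part, and no measurement at hand bears on the reason for it.

As far as these compounds go, it remains open whether a plain phenyl, a methoxy group or a fluorine atom alone on this carbon would keep the number near that of compound 2, which would show how much of the 4-fluorophenyl group is needed. From the compounds shown here alone, whether the same change gives a similar step with a pyrrolidine in place of the dimethylamino group also remains open.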